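The source may hold more compounds than are shown below. What is called first, only, known or untested is meant among the compounds shown, and "the series" means these compounds.

Compound 2 `CCC[C@@H](CCO)Nc1nc(N)nc(C)c1Cc1ccc(CNCCC(N)=O)cc1OC` stands at a limit in an assay on HEK293 cells for agonist activity at Toll-like receptor 8 (Homo sapiens); on this read-out higher numbers stand for an effect only at larger amounts of compound and lower numbers for an effect already at smaller amounts: compound 2 gives > 10000 nM, a limit of the assay rather than a number. Compound 1 `CCC[C@@H](CCO)Nc1nc(N)nc(C)c1Cc1ccc(CN(C)CC(N)=O)cc1OC` also gives > 10000 nM, again a limit. For the measured compounds named here, the step that the two limits leave unreadable from compound 1 to compound 2 therefore stays unreadable, as the limit of > 10000 nM in this assay, at which 2 of the 2 values shown sit, shows, and no measured step on this amine substituent can be read for size. Compound 3 `CCC[C@@H](CCO)Nc1nc(N)nc(C)c1Cc1ccc(CNCCO)cc1OC` carries hydroxy in place of carbamoyl on a saturated chain carbon, two bonds along the chain from an amine nitrogen. With both neighbours at the limit, a step that the limit leaves unreadable from compound 2 to compound 3 is expected, not beyond the scatter. Compound 3 is estimated at 20000 nM, with a range of 5000 nM to 100000 nM.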

Compound 3, half-maximal effective concentration: > 10000 nM
Compound 3 gave a limit, no number; the forecaster's own chance of this, stated with the estimate: 85%; the middle value is on the limit's open side.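

No step among compound 1, compound 2 and compound 3 can be read for size, because each result is a limit rather than a number: the limit of > 10000 nM in this assay, at which 3 of the 3 values shown sit.

The compounds shown leave open whether any change to this amine substituent gives a readable value.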